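Inverting one stereocentre of compound 1

The compounds below may be only part of what the source reports. "The series", "measured", "known", "first", "only" and "open" are said of these compounds alone.

For the measured compounds named here, in a functional assay on MCF7 cells (Homo sapiens) for cytotoxicity, read by MTT assay (on this read-out lower numbers stand for stronger inhibition and higher numbers for weaker inhibition), compound 1 `CC(=O)[C@@]1(C)C(=O)O[C@@H](OC(=O)C(C)(C)C)[C@H]1C` gives 3000 nM, the only value in this small set that is an actual number. Compound 2 `CCO[C@@H]1OC(=O)[C@](C)(C(C)=O)[C@@H]1C` gives > 50000 nM, which is a limit of the assay and not a number. Going by the values given here, the single measured step, an at least 16-fold higher number from compound 1 to compound 2 (1.22 log units; beyond the scatter), is large and beyond the scatter; it puts ethyl in place of (tert-butyl)carbonyl on an oxygen on a saturated carbon. Compound 3 `CC(=O)[C@]1(C)C(=O)O[C@@H](OC(=O)C(C)(C)C)[C@H]1C` differs from compound 1 in another way: the two compounds have the same atoms and bonds and differ only in configuration as drawn: 1 of 3 stereo elements differ; a stereocentre at a saturated ring carbon is drawn S in compound 1 and R in compound 3. Among the compounds with values here, no measured step concerns configuration, so the evidence for this change is thin. Compound 3 keeps the (tert-butyl)carbonyl group that is gone in an at least 16-fold higher number from compound 1 to compound 2 (1.22 log units; beyond the scatter), so a change of that size is not assumed. A moderate move towards a higher number in this assay is expected, with an estimated step of a 2.3-fold higher number from compound 1 to compound 3 (0.37 log units; beyond the scatter). For compound 3 the estimate is 7000 nM, with an expected range from 2000 nM to 30000 nM.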

Compound 3, half-maximal inhibitory concentration: 7000 nM
For compound 3 middle estimate and measured number coincide at the digits printed; the measured number falls inside the stated range.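

In this assay, for the compounds shown here, inverting the stereocentre at a saturated ring carbon, drawn S in compound 1 and R in compound 3, gives a 2.3-fold higher number from compound 1 to compound 3 (0.37 log units; beyond the scatter), the first step in this set that concerns configuration. With the (tert-butyl)carbonyl group kept, both configurations give an actual number, so in these two compounds the inversion alone does not reach the limit of the assay. The step can be assigned to this one stereocentre because no other part of the structure changes: the fact that compounds 1 and 3 differ only in the configuration as drawn.

The compounds shown leave open how the other stereo elements bear on the number, and whether the same inversion would matter with ethyl on that oxygen. Also open, as far as these compounds go, is what a benzoyl group or a longer chain would give there in place of (tert-butyl)carbonyl.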